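Iodophenyl piperazine sulfonamide on a xanthine-like core

The source may report more compounds than this note shows. Statements on the series, on what has been measured and on what is new or still open speak of the compounds shown alone.

Measured so far:
Compound 1 `CCCn1c(=O)[nH]c2nc(-c3ccc(S(=O)(=O)N4CCN(c5ccc(F)cc5)CC4)cc3)[nH]c2c1=O` — > 1000 nM
Compound 2 `CCCn1c(=O)[nH]c2nc(-c3ccc(S(=O)(=O)N4CCN(C(C)c5ccccc5)CC4)cc3)[nH]c2c1=O` — >= 1000 nM

Two compounds share a core carrying a sulfonyl piperazine on a phenyl ring and differ only in the group on the ring amine nitrogen. In an assay on CHO cells for displacement of a labelled ligand from adenosine receptor A1 (Homo sapiens), read by scintillation counting, with a stated time of 90 min, in the presence of a further agent that is not named here (a higher number here means a weaker inhibitor, a lower number a stronger inhibitor), compound 1 gives > 1000 nM, which is a limit of the assay and not a number. In this assay compound 2 gives >= 1000 nM, again a limit and not a number. The step that the two limits leave unreadable from compound 1 to compound 2 is therefore unreadable, since both values sit at limits (the limit of > 1000 nM in this assay, at which 1 of the 2 values shown sits, (the limit of >= 1000 nM in this assay, at which 1 of the 2 values shown sits)). Compound 2 stands at a limit only, with no numerical value to order it against compound 1.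

Compound 3 `CCCn1c(=O)[nH]c2nc(-c3ccc(S(=O)(=O)N4CCN(c5ccc(I)cc5)CC4)cc3)[nH]c2c1=O` has not yet been measured in this assay. Its change from compound 2 is 4-iodophenyl in place of 1-phenylethyl on an amine nitrogen in a ring, returning to an aryl group on the ring nitrogen as in compound 1. For the measured compounds named here, no measured step gives a readable size for this kind of change, and both neighbours rest at limits, so no step beyond the scatter is expected. Compound 3 is expected to give 3000 nM, with a range from 800 nM to 20000 nM. The expected step that the limit leaves unreadable from compound 2 to compound 3 is essentially none, most likely ending at a limit again.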

Compound 3, inhibition constant: > 1000 nM
Compound 3 gave a limit, no number; the forecaster's own chance of this, stated with the estimate: 75%; the middle value lies beyond the limit too.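

Compound 3 in this assay gives > 1000 nM as a limit and not a number. No step can be read from compound 2 to compound 3 or from compound 1 to compound 3, because all three values are limits: the limit of > 1000 nM in this assay, at which 2 of the 3 values shown sit. The compounds shown leave open whether 4-iodophenyl, 4-fluorophenyl and 1-phenylethyl on the amine nitrogen differ at all.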